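This account rests on a few compounds, and the source may have more. Where it says the series, first, only, none or still open, it means among the compounds named here.

Measured so far in a functional assay on BJAB cells (Homo sapiens) for antiproliferative activity, with a stated time of 4 days; on this read-out higher numbers stand for an effect only at larger amounts of compound and lower numbers for an effect already at smaller amounts:
- compound 1 `Cc1c(-c2cc(Cl)cc(Cl)c2)c(C(=O)O)nn1-c1nc(-c2cc(Cl)cc(Cl)c2)c(SC(C)C)s1` gives 2000 nM
- compound 2 `CCOc1ncccc1-c1c(C)nn(-c2nc(-c3ccc(Cl)c(Cl)c3)c(SC(C)C)s2)c1C(=O)O` gives 11000 nM
- compound 3 `COC(=O)c1c(Cc2ccccc2[N+](=O)[O-])c(C)nn1-c1nc(-c2ccc(Cl)c(Cl)c2)c(SC(C)C)s1` gives 93000 nM

Compound 2 stands second highest of the three numbers in this assay. Its nearest neighbour is compound 1, a lower number beyond the scatter; the furthest is compound 3, a higher number, also beyond the scatter. Among the compounds with values here, no single-change pair among the measured compounds is available, so the spread between compound 1 and compound 3 is the only guide to how much the read-out moves within this core.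

The unmeasured compound 4 `Cc1nn(-c2nc(-c3ccc(Cl)c(Cl)c3)c(SC(C)C)s2)c(C(=O)O)c1-c1cccc(Cl)c1` differs from compound 2 in one place: 3-chlorophenyl in place of 2-ethoxypyridin-3-yl on an aromatic carbon.

Within the data shown here, no measured step of this kind exists, so the expectation must rest on the values themselves. Compound 4 is expected to move downward from compound 2 by a 2.4-fold lower number from compound 2 to compound 4 (0.39 log units; beyond the scatter) in this assay, a step beyond the scatter but short of the gap to compound 1. The expectation for compound 4 in this assay is 4500 nM, with a range from 1500 nM to 13000 nM, drawn between compound 2 at 11000 nM and compound 1 at 2000 nM.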

Compound 4, half-maximal effective concentration: 13600 nM
The estimate for compound 4 lay 3.0-fold (0.48 log units) below the measured number; the measured number lies above the stated range.
By their numbers in this assay, from the lowest: compound 1; then compounds 2 and 4 (each within the scatter of the next); then compound 3.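

In this assay, within the data shown here, putting 3-chlorophenyl in place of 2-ethoxypyridin-3-yl gives a 1.2-fold higher number from compound 2 to compound 4 (0.09 log units; within the scatter), the first single-place step, and the read-out does not separate the two groups. On this aromatic carbon, next to the ring atom that bears a carboxy group and the ring atom that bears a methyl group, a six-membered aromatic ring of carbon only with 0 hydrogen-bond acceptors reads the same as a ring with 1 hetero atom and 2 hydrogen-bond acceptors, so for this pair neither the ring nitrogen nor the ethoxy group registers in the number. Nothing at hand gives a reason for this outcome.

The compounds shown leave open whether a ring carrying an amine, such as a piperidine, or a plain hydrogen at this position would read the same as these two aryl groups. Going by these compounds, this is also a single pair on one background, so whether it holds with a primary amide in place of the carboxy group remains open.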